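The source may report more compounds than this note shows. Statements on the series, on what has been measured and on what is new or still open speak of the compounds shown alone.

The measured compounds:

Compound 1, `Nc1cccc(/C=C/c2cccc(O)c2)c1`, gives 43 ug/mL in a functional assay on HT-29 cells (Homo sapiens) for inhibition, read by MTT assay, with a stated time of 2 days; a lower number here means a stronger inhibitor, a higher number a weaker inhibitor.
Compound 2, `Nc1cccc(/C=C/c2ccc(O)cc2)c1`, gives 51 ug/mL in this assay.
Compound 3, `COc1cccc(/C=C/c2cccc(O)c2)c1`, gives 11.5 ug/mL in this assay.

Compound 1 and compound 2 are built of the same atoms joined differently; the difference between the two cores is not broken down here. Their values in this assay lie within the scatter of each other, so nothing separates them. Compound 3 carries the change methoxy in place of amino on an aromatic carbon on the core of compound 1, and the step is a 3.7-fold lower number from compound 1 to compound 3 (0.57 log units; beyond the scatter).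

Compound 4, `COc1cccc(/C=C/c2ccc(O)cc2)c1`, has not yet been measured in this assay. It applies the change methoxy in place of amino on an aromatic carbon to the core of compound 2. Within the data shown here, this is the same change as the one from compound 1 to compound 3, made at a place described in the same words, and in the whole set it occurs twice. Among the measured compounds shown here, with only one measured instance of this change, the expectation for compound 4 rests on that single step together with the value of compound 2.

For the measured compounds named here, for compound 4 the expected step is a 3.6-fold lower number from compound 2 to compound 4 (0.56 log units; beyond the scatter) in this assay, because a 3.7-fold lower number from compound 1 to compound 3 (0.57 log units; beyond the scatter) is the only guide to what the change does, and compound 2 starts from 51 ug/mL, which sits close to the value of compound 1. The estimate for compound 4 in this assay is therefore 14 ug/mL, with a plausible range from 7 ug/mL to 30 ug/mL.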

Compound 4, half-maximal inhibitory concentration: 26 ug/mL
Compound 4: the middle estimate sits 1.9-fold (0.27 log units) below what was measured, and the stated range covers the measured number.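

On the core of compound 2, methoxy in place of amino on an aromatic carbon gives a 2.0-fold lower number from compound 2 to compound 4 (0.29 log units; within the scatter) in this assay, so on this core the change does not stand clear of the scatter, whereas on the core of compound 1 it gives a 3.7-fold lower number from compound 1 to compound 3 (0.57 log units; beyond the scatter). Even so, the two steps point the same way and cannot be told apart, and the series gives no sign that the outcome of this change depends on the core: the same change on two cores in this assay, a 3.7-fold lower number (0.57 log units; beyond the scatter) from compound 1 to compound 3 and a 2.0-fold lower number (0.29 log units; within the scatter) from compound 2 to compound 4, 1.9-fold (0.28 log units) apart, within the scatter of two such steps. This supports carrying the change from one core to the other only loosely, since it rests on two pairs and does not show that the size of the step is the same on both cores, nor that the change has a real effect on the core of compound 2.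

The compounds shown leave open what other groups on that aromatic carbon would give, such as ethoxy, a longer alkoxy chain or a carboxylic acid. They also leave open whether the step would hold on further cores or in cell lines other than the one in this assay.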